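This account rests on a few compounds, and the source may have more. Where it says the series, first, only, none or still open, it means among the compounds named here.

Working notes on the amide series built on the shared core of compound 1, `O=C(/C=C/c1coc2cc(O)ccc2c1=O)NCc1ccc(F)cc1`.

Compound 1 stands at a limit of the assay: in a functional assay on HeLa cells (Homo sapiens) for inhibition, read by MTT assay, with a stated time of 48 h (on this read-out lower numbers stand for stronger inhibition and higher numbers for weaker inhibition), compound 1 gives > 100000 nM, a limit rather than a number. Compound 3, `COc1ccc(CNC(=O)/C=C/c2coc3cc(O)ccc3c2=O)cc1`, likewise gives > 100000 nM in this assay, again a limit. Within the data shown here, compound 2, `COc1ccc2c(=O)c(/C=C/C(=O)NCc3cccc(F)c3)coc2c1`, is the only member with a measured number, 17600 nM in this assay. Among the measured compounds shown here, the one single-point step among the measured compounds, a step that the two limits leave unreadable from compound 1 to compound 3, cannot be read in size, since the limit of > 100000 nM in this assay, at which 2 of the 3 values shown sit, holds both ends of it.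

Compound 4, `O=C(/C=C/c1coc2cc(O)ccc2c1=O)Nc1ccccc1`, differs from compound 1 as follows: phenyl in place of 4-fluorobenzyl on an amide-type nitrogen. For the measured compounds named here, no measured step bears directly on this change, and the core that compound 4 shares with compound 1 and compound 3 has so far given only limits. Compound 4 is therefore expected to sit at or near the same limit in this assay, with the step that the limit leaves unreadable from compound 1 to compound 4 expected to lie within the scatter. The estimate for compound 4 is 150000 nM, in the range 40000 nM to 600000 nM.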

Compound 4, half-maximal inhibitory concentration: 9700 nM
Compound 4: the middle estimate sits 15-fold (1.19 log units) above what was measured; measured number below the stated range.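

In this assay, among these compounds, the amide-type nitrogen is the first place on the shared core where a change gives a measured number: phenyl in place of 4-fluorobenzyl gives an at least 10-fold lower number from compound 1 to compound 4 (1.01 log units; beyond the scatter). Among the compounds shown here, the earlier change on this core, methoxy in place of fluoro, cannot be read in size, so this is the first readable evidence that the group on this nitrogen matters for the series. The new step is only a minimum because one of its ends is a limit: the limit of > 100000 nM in this assay, at which 2 of the 4 values shown sit.

Still open, on these data alone, is whether the step depends on the loss of the fluoro or on the change from benzyl to phenyl, which an unsubstituted benzyl on the same nitrogen would separate. As far as these compounds go, how far the gain extends is also open, for example with a 4-methoxyphenyl or a 2-phenylethyl group there.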